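The source may hold more compounds than are shown below. What is called first, only, known or untested is meant among the compounds shown, and "the series" means these compounds.

Measured so far in an assay on isolated protein for agonist activity at Bile acid receptor (Homo sapiens); a higher number here means a larger maximal response, a lower number a smaller maximal response:

- compound 1, `CC(C)Oc1cc(C(=O)O)cc2sc(N(C)[C@@H]3CC[C@H](OCc4c(-c5c(Cl)cccc5Cl)noc4C4CC4)C3)nc12`, gives 96%
- compound 2, `CC(C)Oc1cc(C(=O)O)cc2sc(N[C@@H]3CC[C@H](OCc4c(-c5c(Cl)cccc5Cl)noc4C4CC4)C3)nc12`, gives 99%

Compound 2 stands at the higher of the two numbers, but the gap to compound 1 is small: a number 3 percentage points higher from compound 1 to compound 2 (within the scatter), so the two cannot be told apart. The step to compound 3, `O=C(O)c1cc(F)c2nc(N[C@@H]3CC[C@H](OCc4c(-c5c(Cl)cccc5Cl)noc4C4CC4)C3)sc2c1`, is a different kind of change: fluoro in place of isopropoxy on an aromatic carbon. Among the measured compounds shown here, no measured step touches this part of the shared core; the one step on record concerns a nitrogen substituent and stays within the scatter. With nothing to lean on, the expectation is that compound 3 keeps a response close to that of compound 2, with a modest downward allowance for an untested change: a number 9 percentage points lower from compound 2 to compound 3 (within the scatter) is the estimated step. Compound 3 is therefore expected to give about 90% in this assay , within a range of 60% to 105%.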

Compound 3, largest response reached (Emax), in percent of the reference or control that the assay uses: 104%
Beside the measured number, compound 3's estimate is 14 percentage points below it; the measured number falls inside the stated range.
By their numbers in this assay, from the lowest: compounds 1, 2 and 3 (each within the scatter of the next).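

In this assay, replacing isopropoxy with fluoro on this aromatic carbon, meta to a carboxy group, gives a number 5 percentage points higher from compound 2 to compound 3 (within the scatter). The maximal response therefore does not depend on keeping isopropoxy, with its 4 heavy atoms and 1 hydrogen-bond acceptor, at this position: a lone fluorine atom, with no hydrogen-bond acceptor, gives a response that cannot be told apart from it, whereas the earlier step changed only a substituent on a nitrogen. No available evidence explains this result. From the compounds shown here alone, what a methoxy, a chloro or an amine at this position would give remains open, as does whether any group here can shift the response beyond the scatter. The largest response also does not show the concentration needed to reach it, so compound 2 and compound 3 could still differ in that respect.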